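The compounds below may be only part of what the source reports. "The series", "measured", "known", "first", "only" and "open" are said of these compounds alone.

Compound 1 (`Cc1sc2ncnc(Oc3ccccc3F)c2c1C`) gives < 5% in an ADME assay on microsomes from liver (Mus musculus) for metabolic stability, read by LC-MS, using NADPH, with a stated time of 30 min (a lower number here means that less of the compound is left, a higher number that more of the compound is left), a limit and not a number. Compound 2 (`Fc1ccccc1Oc1ncnc2scc(C(F)(F)F)c12`) gives < 5%, again a limit. Compound 3 (`CC(C)(C)c1cc2c(Oc3ccccc3F)ncnc2s1`) stands at < 5%, likewise only a limit. Compound 4 (`CC(C)(C)c1sc2ncnc(Oc3ccccc3F)c2c1-c1ccccc1`) differs from compound 3 by phenyl in place of hydrogen on an aromatic carbon, with phenyl in place of hydrogen on an aromatic carbon next to the ring atom that bears a tert-butyl group. Among the measured compounds shown here, no step between measured compounds is available. Because of the limit of < 5% in this assay, at which 3 of the 3 values shown sit, compound 4 is expected to stay close to compound 3 in this assay, with no change beyond the scatter and no clear direction. The expected change is a step that the limit leaves unreadable from compound 3 to compound 4 as estimated here. The estimate for compound 4 is 4%, within an expected range of 1% to 12% for this measurement.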

Compound 4, percent of the compound remaining: 14%
Compound 4: middle estimate off by 10 percentage points, on the low side, and the stated range ends below it.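

In this assay compound 4 gives 14% as a measured number, so the aromatic carbon two ring bonds from the ring sulfur tolerates phenyl. Phenyl in place of hydrogen on that carbon gives a number at least 9 percentage points higher from compound 3 to compound 4 (that floor lies within the scatter) and so a step known only by its floor. No earlier pair could be read, for one reason: the limit of < 5% in this assay, at which 3 of the 4 values shown sit.

Open, on these data alone, is whether an amine or a carboxylic acid on this carbon would leave more of the compound than phenyl does. Also open, as far as these compounds go, is whether phenyl has the same outcome without the neighbouring tert-butyl group.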